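The compounds below may be only part of what the source reports. "The series", "measured", "known", "first", "only" and "open" are said of these compounds alone.

Measured so far:
compound 1, `COc1ccc(/C=C/C[C@@H]2C[C@@H]([C@@H](O)c3ccc(OC)c(OC)c3)CO[C@H]2c2ccc(OC)c(OC)c2)cc1`: 17100 nM
compound 2, `COc1ccc(/C=C/C[C@@H]2C[C@H]([C@H](O)c3ccc(OC)c(OC)c3)CO[C@H]2c2ccc(OC)c(OC)c2)cc1OC`: 28700 nM

Both numbers come from a functional assay on HeLa cells (Homo sapiens) for cytotoxicity, read by WST assay, with a stated time of 48 h; on this read-out higher numbers stand for weaker inhibition and lower numbers for stronger inhibition. In this assay compound 1 gives 17100 nM and compound 2 gives 28700 nM. Compound 2 holds the highest of the two numbers, but its nearest neighbour, compound 1, sits within the scatter of it, so no order between the two can be read from these values; both lie in a weak range.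

The next compound, compound 3, is `COc1ccc(/C=C/C[C@@H]2C[C@@H]([C@@H](O)c3ccc(OC)c(OC)c3)CO[C@H]2c2ccc(OC)c(OC)c2)cc1OC`. It keeps every atom and bond of compound 2, the change being the two compounds have the same atoms and bonds and differ only in configuration as drawn: 2 of 5 stereo elements differ; a stereocentre at a saturated ring carbon is drawn S in compound 2 and R in compound 3; a stereocentre at a saturated chain carbon is drawn S in compound 2 and R in compound 3

Among the compounds with values here, no step between two measured compounds is available, so there is nothing from which the effect of a configurational change can be read off. Given that both measured values fall in the same weak range, the working expectation for this assay is a step in either direction that stays within or only slightly beyond the scatter. The estimated step is a 1.1-fold lower number from compound 2 to compound 3 (0.06 log units; within the scatter), and compound 3 is expected to give about 25000 nM, with a range from 8000 nM to 80000 nM.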

Compound 3, half-maximal inhibitory concentration: 30600 nM
For compound 3 the middle estimate is 1.2-fold (0.09 log units) below the measured one; the range from low to high includes it.
By their numbers in this assay, from the lowest: compounds 1, 2 and 3 (each within the scatter of the next).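

In this assay the pair of compounds that differ at the saturated ring carbon and the saturated chain carbon gives a 1.1-fold higher number from compound 2 to compound 3 (0.03 log units; within the scatter), so drawing these two stereocentres R rather than S does not separate the compounds on this read-out. That reading concerns configuration alone and no other structural feature, for one reason: the fact that compounds 2 and 3 differ only in the configuration as drawn. The series also now has its first step for a substituent, a 1.8-fold higher number from compound 1 to compound 3 (0.25 log units; within the scatter), which shows that methoxy in place of hydrogen on an aromatic carbon does not separate that pair either, with all three compounds remaining in the same weak range.

From the compounds shown here alone, the two stereocentres appear here only as a joint inversion, so the contribution of each one alone stays unknown, and the two differences could offset each other within this single step. Also open, going by these compounds, is whether a different kind of group on the shared core, such as an amine or a carboxylic acid, would produce a step beyond the scatter in this assay.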